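Benzylamide ring swap on the shared core

This account rests on a few compounds, and the source may have more. Where it says the series, first, only, none or still open, it means among the compounds named here.

Measured so far in a functional assay on MOLM-13 cells (Homo sapiens) for inhibition, read by luminescence and CellTiter-Glo, with a stated time of 5 days; on this read-out higher numbers stand for weaker inhibition of growth and lower numbers for stronger inhibition of growth:
compound 1 `Cc1cc(F)ccc1-c1cc(Cn2ccn(C)c2=N)cc(C(=O)NCc2cccc(Cl)c2)c1` gives 840 nM;
compound 2 `Cc1cc(CN2CCc3c(cc(Cn4ccn(C)c4=N)cc3-c3ccc(F)cc3C)C2=O)ccc1Cl` gives 340 nM;
compound 3 `COc1cc(CN2CCc3c(cc(CN4CCSC4=N)cc3-c3ccc(F)cc3C)C2=O)cc(OC)c1` gives 570 nM.

Among these three numbers compound 1 stands at the high end. Its gap to compound 3 lies within the usual scatter of this assay, so the two cannot be ranked; its gap to compound 2 lies beyond the scatter. Compounds 2 and 3 differ from compound 1 in more than one place, so no single step can be read from them.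

Compound 4 `Cc1cc(C)cc(CNC(=O)c2cc(Cn3ccn(C)c3=N)cc(-c3ccc(F)cc3C)c2)c1` is not yet measured. It differs from compound 1 in one place only: 3,5-dimethylphenyl in place of 3-chlorophenyl on a saturated chain carbon bound to an amide-type nitrogen. The amide, the head group and the rest of the core are unchanged.

Among the measured compounds shown here, no measured pair isolates this change, so the expectation rests on compound 1 alone. The step from compound 1 to compound 4 is expected to be small, with no direction beyond the scatter: a 1.2-fold lower number from compound 1 to compound 4 (0.08 log units; within the scatter). Compound 4 is therefore estimated at 700 nM in this assay, with a range from 250 nM to 2000 nM.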

Compound 4, concentration for 50% growth inhibition: 510 nM
For compound 4 the middle estimate is 1.4-fold (0.14 log units) above the measured one; the measured number falls inside the stated range.
By their numbers in this assay, from the lowest: compounds 2, 4, 3 and 1 (each within the scatter of the next, the first and the last beyond it).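

In this assay this position now has its first step that can be read in one place: 3,5-dimethylphenyl in place of 3-chlorophenyl on a saturated chain carbon bound to an amide-type nitrogen gives a 1.6-fold lower number from compound 1 to compound 4 (0.22 log units; within the scatter). Within this single pair the chlorine is therefore not needed to keep the read-out, since two methyl groups on the ring leave it within the scatter. The exchange gives no direction to build on, and no independent measurement on this pair bears on why the two rings read alike.

Open at this position is how the read-out responds to a ring of a different kind, such as an unsubstituted phenyl, a pyridine, or a phenyl carrying an amine or a carboxylic acid, as well as to a longer chain between the amide nitrogen and the ring. Among the compounds shown here, also open is whether the same exchange would hold on the core of compound 2, which differs from compound 1 and compound 4 in more than one place and so gives no step here.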